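Larger carbonyl substituent and tolerated concentration

The source may report more compounds than this note shows. Statements on the series, on what has been measured and on what is new or still open speak of the compounds shown alone.

Compound 1 `CCC(=O)N1CCN(c2cc(NCCN)c3ccccc3n2)CC1` is the reference of the series. In an ADME assay on HEp-2 cells (Homo sapiens) for cytotoxicity, read by CCK-8 assay, with a stated time of 6 days (a higher number here means that more compound is tolerated, a lower number that less compound is tolerated), compound 1 gives > 100000 nM, which is a limit of the assay and not a number. Compound 2 `CS(=O)(=O)N1CCN(c2cc(NCCN)c3ccccc3n2)CC1` carries methylsulfonyl in place of propanoyl on an amine nitrogen in a ring; in this assay compound 2 gives > 100000 nM, again a limit. Compound 3 `CC(C)C(=O)N1CCN(c2cc(NCCN)c3ccccc3n2)CC1` carries methyl in place of hydrogen on a saturated chain carbon bound to a carbonyl carbon and a saturated chain carbon; in this assay compound 3 gives > 100000 nM, also a limit. The steps a step that the two limits leave unreadable from compound 1 to compound 2, a step that the two limits leave unreadable from compound 1 to compound 3 and a step that the two limits leave unreadable from compound 2 to compound 3 have no readable size, because of the limit of > 100000 nM in this assay, at which 3 of the 3 values shown sit.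

Compound 4 `NCCNc1cc(N2CCN(C(=O)C3(c4ccccc4)CCCC3)CC2)nc2ccccc12` is not yet measured. Relative to compound 1 the change is 1-phenylcyclopentyl in place of ethyl on a carbonyl carbon. This is a far larger change than any of the measured ones, which varied the same region with small groups and left every value at the limit. The measured steps bear on it only in that small variation here did not move tolerance into the readable range; they give no direction for a change of this size. The expectation for compound 4 in this assay is 100000 nM, with a range of 30000 nM to 300000 nM, most likely reported again as a limit. The step of a number no higher from compound 1 to compound 4 (the limit leaves the size open) is expected to be none beyond the scatter.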

Compound 4, half-maximal cytotoxic concentration: > 100000 nM
Compound 4 was reported as a limit (the forecaster's own chance of this, stated with the estimate: 60%); the middle value sits exactly at the limit.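

In this assay compound 4 gives > 100000 nM as a limit and not a number. The steps from compound 1 and compound 3 to compound 4 cannot be read, because all values stand at the same limit: the limit of > 100000 nM in this assay, at which 4 of the 4 values shown sit. The compounds shown leave open whether any group on the carbonyl carbon brings a value into the readable range.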